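Thiazole aryl exchange in the pyrazole carboxylic acid series

The source may report more compounds than this note shows. Statements on the series, on what has been measured and on what is new or still open speak of the compounds shown alone.

Of the compounds shown here, three have been measured in a functional assay on BJAB cells (Homo sapiens) for antiproliferative activity, with a stated time of 4 days; on this read-out lower numbers stand for an effect already at smaller amounts and higher numbers for an effect only at larger amounts of compound. Compound 1 `Cc1nn(-c2nc(-c3ccc(Cl)c(Cl)c3)c(SC(C)C)s2)c(C(=O)O)c1-c1ccccc1` gives 3000 nM. Compound 2 `Cc1c(-c2cc(Cl)cc(Cl)c2)c(C(=O)O)nn1-c1nc(-c2cc(Cl)cc(Cl)c2)c(SC(C)C)s1` gives 2000 nM, the second highest of the three numbers and within the scatter of compound 1. Compound 3 `Cc1cc(-c2c(C)nn(-c3nc(-c4ccc(Cl)c(Cl)c4)c(SC(C)C)s3)c2C(=O)O)cc(C)n1` gives 580 nM. Going by the values given here, the only step so far between two compounds that differ in one place is a 5.2-fold lower number from compound 1 to compound 3 (0.71 log units; beyond the scatter), a change of the aryl group on the pyrazole.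

Compound 4 `Cc1c(-c2cc(Cl)cc(Cl)c2)c(C(=O)O)nn1-c1nc(-c2ccc3nccn3c2)c(SC(C)C)s1` is not yet measured. It differs from compound 2 by a group of 9 heavy atoms (7 carbon, 2 nitrogen; one five-membered aromatic ring with 2 hetero atoms, one six-membered aromatic ring with 1 hetero atom) in place of a group of 8 heavy atoms (6 carbon, 2 chlorine; one six-membered aromatic ring of carbon only), on an aromatic carbon. Among the compounds with values here, this change sits on the thiazole, not on the pyrazole where the step from compound 1 to compound 3 took place, so no measured step bears on it directly. Within the data shown here, the one step that exists shows that exchanging a carbon-only ring for a nitrogen-containing ring lowered the number in this assay by a modest amount; compound 3 carries that change against compound 1 and compound 2 shows nothing either way about the thiazole position.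

The expectation for compound 4 is therefore a small improvement, a 1.7-fold lower number from compound 2 to compound 4 (0.22 log units; within the scatter), with wide uncertainty because it rests only on a 5.2-fold lower number from compound 1 to compound 3 (0.71 log units; beyond the scatter) at another place. Compound 4 is estimated at 1200 nM, in the range 400 nM to 4000 nM.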

Compound 4, half-maximal effective concentration: "not active" (no number reported)
No number was reported for compound 4; no gap can be computed for the estimate.
By their numbers in this assay, from the lowest: compound 3; then compounds 2 and 1 (each within the scatter of the next).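

In this assay, going by these compounds alone, compound 4 is reported as not active, without a number, so no step from compound 2 to compound 4 can be read. No data shown here bear on this result. The compounds shown leave open whether any other group in place of 3,5-dichlorophenyl at this place gives a measurable number.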